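Vero tolerance notes: aryl variation on the carbonyl carbon

A few compounds are considered here, and "the series" means these few. Any claim that something is new, unique, unknown or untested is made for them only; others in the source may bear on it.

Compound 3 `COC(=O)c1cc(-c2cccc(NC(=O)c3ccc(/C=C/C(=O)c4ccc(OC)cc4OC)cc3)c2)on1` in an ADME assay on Vero cells (Chlorocebus sabaeus) for cytotoxicity, read by MTT assay, with a stated time of 72 h (a lower number here means that less compound is tolerated, a higher number that more compound is tolerated), gives > 50 ug/mL, which is a limit of the assay rather than a number. Compound 2 `COC(=O)c1cc(-c2cccc(NC(=O)c3ccc(/C=C/C(=O)c4ccc(C)c(F)c4)cc3)c2)on1` in this assay gives > 50 ug/mL, likewise a limit. Compound 1 `COC(=O)c1cc(-c2cccc(NC(=O)c3ccc(/C=C/C(=O)c4cccc(Cl)c4)cc3)c2)on1` in this assay gives > 2.5 ug/mL, again a limit. Two of the three values sit at the limit of > 50 ug/mL in this assay, at which 2 of the 3 values shown sit, and one at the limit of > 2.5 ug/mL in this assay, at which 1 of the 3 values shown sits, so compound 3 stands at the upper limit alongside compound 2, and no ordering among the three compounds can be read. The steps a step that the two limits leave unreadable from compound 1 to compound 2, a step that the two limits leave unreadable from compound 1 to compound 3 and a step that the two limits leave unreadable from compound 2 to compound 3 are all left unreadable by the limits, so none of them has a known size.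

Compound 4 `COC(=O)c1cc(-c2cccc(NC(=O)c3ccc(/C=C/C(=O)c4ccc(Br)cc4)cc3)c2)on1` differs from compound 3 by 4-bromophenyl in place of 2,4-dimethoxyphenyl on a carbonyl carbon. All three measured steps change the aryl group on the carbonyl carbon, as this one does, yet none carries a readable size, so no direction beyond the scatter is expected in this assay. Compound 4 is expected in this assay at 50 ug/mL, within 10 ug/mL to 100 ug/mL. This estimate means an expected step of a number no higher from compound 3 to compound 4 (the limit leaves the size open).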

Compound 4, half-maximal cytotoxic concentration: > 20 ug/mL
Compound 4 was reported as a limit (the forecaster's own chance of this, stated with the estimate: 70%); the middle value does not contradict the limit.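

In this assay compound 4 gives > 20 ug/mL, which is a limit of the assay. Going by these compounds alone, compounds 1, 2, 3 and 4 all stand as limits, and no step to compound 4 can be read. The compounds shown leave open whether changing the aryl group on the carbonyl carbon alters tolerance at all.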